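The source may hold more compounds than are shown below. What is called first, only, known or untested is meant among the compounds shown, and "the series" means these compounds.

The measured compounds: compound 1 `CC(C)n1ncc2c(C(=O)N3CCc4cccnc43)cc(-c3cccs3)nc21` with 50000 nM in an ADME assay on LLC-MK2 cells (Macaca mulatta) for cytotoxicity, read by spectrophotometry and crystal violet staining, with a stated time of 4 days; on this read-out lower numbers stand for higher toxicity in this test and higher numbers for lower toxicity in this test; compound 2 `CC(C)n1ncc2c(C(=O)Nc3cc(C(N)=O)ccc3F)cc(-c3cccs3)nc21` with 25000 nM in this assay; compound 3 `CC(C)n1ncc2c(C(=O)Nc3ccncn3)cc(-c3cccs3)nc21` with 50000 nM in this assay.

Compound 3 stands level with compound 1 at the digits shown, and the step of a 2.0-fold higher number from compound 2 to compound 3 (0.30 log units; within the scatter) is within the scatter, so all three sit in one band. Compound 4 `CC(C)n1ncc2c(C(=O)Nc3ncccn3)cc(-c3cccs3)nc21` differs from compound 3 by pyrimidin-2-yl in place of pyrimidin-4-yl on an amide-type nitrogen. Both changes at the amide nitrogen known so far, no change at the digits printed from compound 1 to compound 3 (within the scatter) and a 2.0-fold higher number from compound 2 to compound 3 (0.30 log units; within the scatter), stayed within the scatter, and the present change is smaller than either. No step beyond the scatter is therefore expected in this assay, no change at the digits printed from compound 3 to compound 4 (within the scatter). Compound 4 is estimated at 50000 nM, with a range of 25000 nM to 100000 nM.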

Compound 4, half-maximal cytotoxic concentration: 75000 nM
Compound 4: middle estimate off by 1.5-fold (0.18 log units), on the low side, within the range that was stated.
By their numbers in this assay, from the lowest: compounds 2, 1, 3 and 4 (each within the scatter of the next, the first and the last beyond it).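

In this assay, the swap between the two pyrimidinyl isomers on the amide-type nitrogen gives a 1.5-fold higher number from compound 3 to compound 4 (0.18 log units; within the scatter), and the step from the fused amide group gives a 1.5-fold higher number from compound 1 to compound 4 (0.18 log units; within the scatter), so neither leaves the band. This position now shows its first step beyond the scatter, a 3.0-fold higher number from compound 2 to compound 4 (0.48 log units; beyond the scatter), with pyrimidin-2-yl in place of 5-carbamoyl-2-fluorophenyl. Nothing reported here bears on why the numbers fall this way. The compounds shown leave open how a simple alkyl amine or a carboxylic acid on the amide-type nitrogen would read in this assay, and whether these steps would hold with other changes on the shared core.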